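This account rests on a few compounds, and the source may have more. Where it says the series, first, only, none or still open, it means among the compounds named here.

In a functional assay on MOLT-4 cells (Homo sapiens) for antiproliferative activity (on this read-out lower numbers stand for stronger inhibition and higher numbers for weaker inhibition), compound 2 `COc1cc(C(=O)c2sc(-c3ccc(Cl)cc3)cc2N)cc(OC)c1OC` gives 77 nM, the higher of the two actual numbers in the series. Compound 3 `COc1cc(C(=O)c2sc(-c3cccc([N+](=O)[O-])c3)cc2N)cc(OC)c1OC` gives 7.5 nM. Compound 1 `COc1cc(C(=O)c2sc(-c3ccc(-c4ccccc4)cc3)cc2N)cc(OC)c1OC` gives > 10000 nM, which is a limit of the assay and not a number.

Compound 4 `COc1cc(C(=O)c2sc(-c3ccccc3Cl)cc2N)cc(OC)c1OC`, still unmeasured, carries 2-chlorophenyl in place of 4-chlorophenyl on an aromatic carbon, next to the ring sulfur (2-chlorophenyl in place of 4-chlorophenyl on an aromatic carbon).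

Two measured changes to this substituent bear on it, and both are large: an at least 120-fold lower number from compound 1 to compound 2 (2.11 log units; beyond the scatter) and a 10-fold lower number from compound 2 to compound 3 (1.01 log units; beyond the scatter). With only these two steps, the size of the next step is better supported than its direction. The expected step is a 2.6-fold higher number from compound 2 to compound 4 (0.41 log units; beyond the scatter), beyond the scatter and tentatively towards a higher number. For compound 4, the estimated value is 200 nM, with an expected range of 25 nM to 1500 nM.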

Compound 4, half-maximal inhibitory concentration: 17 nM
Estimate against measurement, compound 4: 12-fold (1.07 log units) above; measured number below the stated range.
By their numbers in this assay, from the lowest: compound 3; then compound 4; then compound 2. At a limit, above all of these: compound 1.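

Moving the chlorine around the phenyl, with the atoms unchanged, is enough to shift the read-out in this assay: the change to 2-chlorophenyl gives a 4.5-fold lower number from compound 2 to compound 4 (0.66 log units; beyond the scatter). This position therefore responds to where a substituent sits on the phenyl, not only to which group it carries. The 2-chlorophenyl does not match the 3-nitrophenyl, with a 2.3-fold higher number from compound 3 to compound 4 (0.36 log units; beyond the scatter), and nothing shown gives a cause for either step.

On these data alone, what a 3-chlorophenyl or a 4-nitrophenyl would give remains open, so the contribution of the group and that of its place on the phenyl cannot yet be separated.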